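Swapping the Ethylsulfanyl Group of Compound 3

This account rests on a few compounds, and the source may have more. Where it says the series, first, only, none or still open, it means among the compounds named here.

Compound 1 `Cc1nc2c(OCc3ccccc3)cccn2c1C#N` gives 25% in a functional assay on the whole organism with Rattus norvegicus as the target, with a stated time of 4 h, at a dose of 40 mg/kg by the intraperitoneal route; on this read-out higher numbers stand for more inhibition at the one dose given (going by the name of the read-out) and lower numbers for less inhibition.
Compound 2 `COCc1c(C)nc2c(OCc3ccccc3)cccn12` gives 99% in this assay.
Compound 3 `CCSCc1c(C)nc2c(OCc3ccccc3)cccn12` gives 36% in this assay.

Compound 3 stands second highest of these three numbers: the change was a number 11 percentage points higher from compound 1 to compound 3 (beyond the scatter) and a number 63 percentage points lower from compound 2 to compound 3 (beyond the scatter). Compound 4 `Cc1nc2c(OCc3ccccc3)cccn2c1COC(=O)c1cccnc1` differs from compound 3 in one place: ((pyridin-3-yl)carbonyl)oxy in place of ethylsulfanyl on a saturated chain carbon bound to an aromatic carbon. The step that bears on this is the one at the same chain carbon, a number 63 percentage points lower from compound 2 to compound 3 (beyond the scatter), a large one, showing that this position moves the number strongly; the step of a number 74 percentage points higher from compound 1 to compound 2 (beyond the scatter) was also large. A large step in this assay is therefore possible, most likely upward, though the entering group is far bigger than methoxy. Compound 4 is expected to give 60%, between 25% and 95%, an estimated step of a number 24 percentage points higher from compound 3 to compound 4 (beyond the scatter).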

Compound 4, a percentage reported as inhibition, in the whole organism at one dose (the size of the read-out at that dose, not a potency): 87%
Compound 4: middle estimate off by 27 percentage points, on the low side; measured number inside the range.
By their numbers in this assay, from the lowest: compound 1; then compound 3; then compound 4; then compound 2.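

In this assay, the large step of a number 51 percentage points higher from compound 3 to compound 4 (beyond the scatter) shows that a much bigger group carrying an aromatic ring can sit on this chain carbon and still give a high number. The modest step of a number 12 percentage points lower from compound 2 to compound 4 (beyond the scatter) places the two groups joined through oxygen fairly close together, while ethylsulfanyl, joined through sulfur, stands well apart from both. Nothing available gives a reason for these differences. From the compounds shown here alone, it remains open whether benzoyloxy would match ((pyridin-3-yl)carbonyl)oxy, which would test the ring nitrogen. Going by these compounds, how an amine or a carboxylic acid would fare on this carbon also remains open.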